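The source may report more compounds than this note shows. Statements on the series, on what has been measured and on what is new or still open speak of the compounds shown alone.

Measured so far in a functional assay on A549 cells (Homo sapiens) for antiproliferative activity, read by MTT assay, with a stated time of 72 h; on this read-out higher numbers stand for weaker inhibition and lower numbers for stronger inhibition

- compound 1 `O=C(N/N=C/c1ccc(Br)cc1)Nc1ccc(Oc2ccnc3[nH]ccc23)c(F)c1` gives 820 nM
- compound 2 `O=C(N/N=C/c1ccc(Cl)c(Cl)c1)Nc1ccc(Oc2ccnc3[nH]ccc23)c(F)c1` gives 2650 nM
- compound 3 `O=C(N/N=C/c1ccc(O)c(Br)c1)Nc1ccc(Oc2ccnc3[nH]ccc23)c(F)c1` gives 9250 nM

Compound 1 has the lowest number of the three, which makes it the strongest inhibitor here. Compound 4 `O=C(N/N=C/c1ccc(Br)cc1)Nc1ccc(Oc2ccnc3[nH]ccc23)cc1` differs from it by hydrogen in place of fluoro on an aromatic carbon and is still unmeasured. Within the data shown here, no measured step touches that carbon. The steps from compound 1 replace 4-bromophenyl instead, with 3,4-dichlorophenyl (a 3.2-fold higher number from compound 1 to compound 2 (0.51 log units; beyond the scatter)) and with 3-bromo-4-hydroxyphenyl (an 11-fold higher number from compound 1 to compound 3 (1.05 log units; beyond the scatter)), so they show that the numbers can move but say nothing direct about fluoro. The expected change in this assay is therefore small, within the scatter and perhaps slightly upward (a 1.3-fold higher number from compound 1 to compound 4 (0.13 log units; within the scatter)). Compound 4 is estimated at 1100 nM with a likely range from 400 nM to 3000 nM when measured.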

Compound 4, half-maximal inhibitory concentration: 640 nM
Beside the measured number, compound 4's estimate is 1.7-fold (0.24 log units) above it; the measured number falls inside the stated range.
By their numbers in this assay, from the lowest: compounds 4 and 1 (each within the scatter of the next); then compound 2; then compound 3.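

In this assay, hydrogen in place of fluoro on this aromatic carbon gives a 1.3-fold lower number from compound 1 to compound 4 (0.11 log units; within the scatter) and so stays within the scatter. Among these compounds, this is the first measured change at this position, as the earlier steps all replaced the 4-bromophenyl group, and in this pair the fluoro can go without a measurable shift. Nothing measured here gives a reason for this result.

From the compounds shown here alone, whether a chloro, methoxy or amine group on this carbon would move the number remains open. Also open, going by these compounds, is whether hydrogen and fluoro would read alike with 3,4-dichlorophenyl or 3-bromo-4-hydroxyphenyl in place of 4-bromophenyl.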